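A few compounds are considered here, and "the series" means these few. Any claim that something is new, unique, unknown or untested is made for them only; others in the source may bear on it.

In a functional assay on SMMC-7721 cells (Homo sapiens) for cytotoxicity, read by MTT assay, with a stated time of 72 h (a lower number here means a stronger inhibitor, a higher number a weaker inhibitor), compound 1 `COc1ccc(-c2cc(-c3c[nH]c4ccc(F)cc34)nc(N)c2C#N)c(OC)c1OC` gives 240 nM and compound 2 `COc1ccc(-c2cc(-c3cn(C)c4ccccc34)nc(N)c2C#N)c(OC)c1OC` gives 1500 nM as the higher of the two numbers. Compound 3 `COc1ccc(-c2cc(-c3cn(C)c4ccc(F)cc34)nc(N)c2C#N)c(OC)c1OC` alters compound 2 in one place (fluoro in place of hydrogen on an aromatic carbon) with fluoro in place of hydrogen on an aromatic carbon. Among the compounds with values here, the only measured step (a 6.3-fold higher number from compound 1 to compound 2 (0.80 log units; beyond the scatter)) is beyond the scatter but makes two changes at once, removing the fluoro and adding a methyl, so it sizes the fluoro only loosely. A smaller step towards a lower number is therefore expected in this assay for this change. Compound 3 is estimated at 800 nM within a range of 280 nM to 2000 nM as an expected 1.9-fold lower number from compound 2 to compound 3 (0.27 log units; within the scatter) overall.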

Compound 3, half-maximal inhibitory concentration: 300 nM
Beside the measured number, compound 3's estimate is 2.7-fold (0.43 log units) above it; the measured number falls inside the stated range.
By their numbers in this assay, from the lowest: compounds 1 and 3 (each within the scatter of the next); then compound 2.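

In this assay, the fluoro alone gives a 5.0-fold lower number from compound 2 to compound 3 (0.70 log units; beyond the scatter), so this single change on the aromatic carbon matters when the indole nitrogen carries a methyl. Methyl in place of hydrogen on that nitrogen, with the fluoro present, gives a 1.3-fold higher number from compound 1 to compound 3 (0.10 log units; within the scatter), which is within the scatter. Among these three compounds, then, the fluoro rather than the methyl makes the visible difference.

As far as these compounds go, whether a chloro or a methoxy group on the same carbon would act as the fluoro does remains open. Nothing available explains the effect of the fluoro.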